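A few compounds are considered here, and "the series" means these few. Any claim that something is new, unique, unknown or untested is made for them only; others in the source may bear on it.

Compound 3, `COc1cc(-c2cc(/C=C/C(=O)c3ccc(C)cc3)nc3cc(-c4ccccc4)nn23)cc(OC)c1OC`, is the reference point of this account. In an ADME assay on HEK293 cells (Homo sapiens) for antiproliferative activity, read by MTT assay, with a stated time of 24 h (on this read-out lower numbers stand for stronger inhibition and higher numbers for weaker inhibition), compound 3 gives 50400 nM, the highest of the two numbers reported so far; its nearest neighbour is compound 2, `COc1cc(-c2cc(C(=O)/C=C/c3ccccc3)nc3cc(-c4ccccc4)nn23)cc(OC)c1OC`, which in this assay gives 44800 nM, and the step of a 1.1-fold higher number from compound 2 to compound 3 (0.05 log units; within the scatter) lies within the scatter of repeated measurements. Compound 1, `COc1cc(C(=O)/C=C/c2cc(-c3cc(OC)c(OC)c(OC)c3)n3nc(-c4ccccc4)cc3n2)cc(OC)c1OC`, is reported in this assay only as a limit, >= 100000 nM, which is a boundary of the measurement rather than a number (the limit of >= 100000 nM in this assay, at which 1 of the 3 values shown sits). Measured against that limit, the step of an at least 1.9-fold lower number from compound 1 to compound 3 (0.29 log units; that floor lies within the scatter) reaches only a floor that sits within the scatter.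

Compound 4, `COc1cc(-c2cc(/C=C/C(=O)c3ccccc3)nc3cc(-c4ccccc4)nn23)cc(OC)c1OC`, has not yet been measured in this assay. It differs from compound 3 in one place: hydrogen in place of methyl on an aromatic carbon. Neither measured step involves the loss of a methyl group, and the step that does touch the 4-methylphenyl group, from compound 2 to compound 3, is itself within the scatter. Compound 4 is therefore expected to sit close to compound 3, with a step of a 1.1-fold lower number from compound 3 to compound 4 (0.03 log units; within the scatter) that is estimated to stay within the scatter. On this basis compound 4 is estimated at 47000 nM in this assay, with an expected range from 22000 nM to 100000 nM.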

Compound 4, half-maximal inhibitory concentration: >= 100000 nM
Compound 4: no number, only a limit (the forecaster's own chance of this, stated with the estimate: 15%); middle value at least 2.1-fold (0.32 log units) from the limit.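

With hydrogen in place of methyl, para to a large group, the step of an at least 1.9-fold higher number from compound 3 to compound 4 (0.29 log units; that floor lies within the scatter) reaches only a floor, so this change alone does not establish that the methyl group matters at this position. The other new step, an at least 2.2-fold higher number from compound 2 to compound 4 (0.34 log units; beyond the scatter), is the first step shown here to pass beyond the scatter, whereas the exchange that carries the 4-methylphenyl group, a 1.1-fold higher number from compound 2 to compound 3 (0.05 log units; within the scatter), stays within it, so the two exchanges are separated only by this methyl group and read differently. In this assay compound 4 is reported only as a limit, and no number places it: the limit of >= 100000 nM in this assay, at which 2 of the 4 values shown sit.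

The step between compound 1 and compound 4 cannot be read, and the true size of the steps to compound 4 remains unknown, so the compounds shown give only the floors of the effect of losing the methyl group. Going by these compounds, what a chlorine atom, an amine or a carboxylic acid on this aromatic carbon would give in this assay also stays open, as does whether a longer chain there would behave as methyl does.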